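The source may hold more compounds than are shown below. What is called first, only, known or untested is meant among the compounds shown, and "the series" means these compounds.

In a functional assay on FaDu cells (Homo sapiens) for cytotoxicity, read by MTT assay, with a stated time of 72 h (on this read-out lower numbers stand for higher toxicity in this test and higher numbers for lower toxicity in this test), compound 3 (`COc1ccc(NC(=O)C(=O)c2cn(C(C)C)c3ccccc23)cn1`) gives 85 nM. Compound 1 (`COc1ncc(NC(=O)C(=O)c2cn(C(C)C)c3ccccc23)cn1`) gives 171 nM, and the two are separated by a 2.0-fold lower number from compound 1 to compound 3 (0.30 log units; within the scatter), with 6-methoxypyridin-3-yl in place of 2-methoxypyrimidin-5-yl on an amide-type nitrogen. Compound 2 (`COc1ccc(NC(=O)C(=O)c2cn(C(C)C)c3cccc(OC)c23)cn1`) stands far from both at 7780 nM, and the move to compound 3 is a 92-fold lower number from compound 2 to compound 3 (1.96 log units; beyond the scatter), with hydrogen in place of methoxy on an aromatic carbon.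

Compound 4 (`COc1ccc(NC(=O)C(=O)c2cn(CC3CCO3)c3ccccc23)cn1`) has (oxetan-2-yl)methyl in place of isopropyl on an aromatic nitrogen. Neither measured step touches that nitrogen, so the data hold no direct measure of this change. They show only that a single replacement on this core can leave the number within the scatter or move it a long way. For the measured compounds named here, the one large step, a 92-fold lower number from compound 2 to compound 3 (1.96 log units; beyond the scatter), read backwards, pairs a bigger substituent with a higher number, but it lies at another place and is weak guidance. A moderate rise is therefore expected, towards lower toxicity in this test, and a result within the scatter would remain possible. The expected step is a 3.3-fold higher number from compound 3 to compound 4 (0.52 log units; beyond the scatter). Compound 4 is estimated at 280 nM, with an expected range from 60 nM to 1300 nM.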

Compound 4, concentration lethal to 50% of the cells: 686 nM
Compound 4: the middle estimate sits 2.5-fold (0.39 log units) below what was measured; low and high end bracket the measured number.
By their numbers in this assay, from the lowest: compounds 3 and 1 (each within the scatter of the next); then compound 4; then compound 2.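

The result gives the first direct measure at this aromatic nitrogen: in this assay, (oxetan-2-yl)methyl in place of isopropyl gives an 8.1-fold higher number from compound 3 to compound 4 (0.91 log units; beyond the scatter), so the number does respond to the group placed here, and it moves towards lower toxicity in this test. The step lies beyond the scatter yet is much smaller than a 92-fold lower number from compound 2 to compound 3 (1.96 log units; beyond the scatter), so among the compounds shown this change on the nitrogen costs less than adding methoxy on the aromatic carbon of the core. Nothing available bears on why this replacement raises the number.

With a single pair at this nitrogen, the compounds shown leave open whether the rise goes with the four-membered ring, with its oxygen or simply with the larger group that enters. On these data alone, a cyclobutylmethyl group, which keeps a four-membered ring but carries only carbon, and a plain ethyl chain on the same nitrogen would begin to separate these readings, and it also stays open whether the step would hold with the 2-methoxypyrimidin-5-yl group of compound 1 on the amide-type nitrogen.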